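The source may hold more compounds than are shown below. What is called first, only, known or untested is meant among the compounds shown, and "the series" means these compounds.

Values measured in a functional assay on HepG2 cells (Homo sapiens) for inhibition, read by MTT assay, with a stated time of 48 h (a higher number here means a weaker inhibitor, a lower number a stronger inhibitor), are as follows

- compound 1 `CS(=O)(=O)c1ccc(-c2nc3ccccn3c2Sc2ccccc2)cc1` gives 13200 nM
- compound 2 `Cc1ccc(-c2nc3ccccn3c2Sc2ccccc2)cc1` gives 67900 nM
- compound 3 `c1ccc(Sc2c(-c3ccccc3)nc3ccc(-c4ccccc4)cn23)cc1` gives 47800 nM

Compound 2 has the highest number of the three, but it lies within the scatter of compound 3 and clearly above compound 1. The next compound is compound 4 `CSc1ccc(-c2nc3ccccn3c2Sc2ccccc2)cc1`, which carries methylsulfanyl in place of methyl on an aromatic carbon, para to a large group (methylsulfanyl in place of methyl on an aromatic carbon).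

Within the data shown here, only one measured step bears on this place. The modest step of a 5.1-fold higher number from compound 1 to compound 2 (0.71 log units; beyond the scatter) goes with methyl replacing methylsulfonyl. Among the measured compounds shown here, compound 3 differs from compound 2 elsewhere and offers no step here. Methylsulfanyl has not yet been measured at this place, so the step from compound 1 gives only a loose guide, and a value between those of compound 1 and compound 2 seems likely. The expected change a 1.9-fold lower number from compound 2 to compound 4 (0.28 log units; within the scatter) is toward a lower number and is expected to stay within the scatter. For compound 4 the estimated value is 36000 nM with an expected range of 14000 nM to 85000 nM in this measurement.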

Compound 4, half-maximal inhibitory concentration: 7600 nM
Compound 4: middle estimate off by 4.7-fold (0.68 log units), on the high side, outside the stated range (below it).
By their numbers in this assay, from the lowest: compounds 4 and 1 (each within the scatter of the next); then compounds 3 and 2 (each within the scatter of the next).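

In this assay, the change on the aromatic carbon para to a large group gives an 8.9-fold lower number from compound 2 to compound 4 (0.95 log units; beyond the scatter), so a lower number at this place does not require the sulfonyl group. Methylsulfanyl and methylsulfonyl cannot be told apart here, with a 1.7-fold lower number from compound 1 to compound 4 (0.24 log units; within the scatter), and among the three groups compared at this place, methyl alone stands apart. The data offer no measurement that would explain this difference.

On these data alone, whether sulfur itself matters at this place remains open: methoxy, or a longer chain such as ethylsulfanyl, would bear on that question. Also open, as far as these compounds go, is whether the step from methyl to methylsulfanyl carries over to a core with further substitution, such as the additional phenyl of compound 3.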